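From Dimethylamino to Diethylamino on the Side Chain

The source may report more compounds than this note shows. Statements on the series, on what has been measured and on what is new or still open speak of the compounds shown alone.

In a functional assay on HL60/MX2 cells (Homo sapiens) for antiproliferative activity, read by MTT assay, with a stated time of 48 h (on this read-out higher numbers stand for weaker inhibition and lower numbers for stronger inhibition), compound 1 `Cn1c(N)c(-c2nc3ccccc3[nH]2)c2nc(C#N)c(C#N)nc21` gives > 50000 nM, which is a limit of the assay and not a number. Compound 2 `CN1CCN(CCn2c(N)c(-c3nc4ccccc4[nH]3)c3nc(C#N)c(C#N)nc32)CC1` gives 6490 nM. Compound 3 `CN(C)CCCn1c(N)c(-c2nc3ccccc3[nH]2)c2nc(C#N)c(C#N)nc21` gives 2390 nM, the lowest of the two actual numbers. Compound 4 `CCN(CC)CCCn1c(N)c(-c2nc3ccccc3[nH]2)c2nc(C#N)c(C#N)nc21` differs from compound 3 by one change: diethylamino in place of dimethylamino on a saturated chain carbon, three bonds along the chain from an aromatic nitrogen. Diethylamino stands in place of dimethylamino, three bonds along the chain from an aromatic nitrogen. Adding a side chain produced large shifts, an at least 20-fold lower number from compound 1 to compound 3 (1.32 log units; beyond the scatter) and an at least 7.7-fold lower number from compound 1 to compound 2 (0.88 log units; beyond the scatter). Within the data shown here, the closest precedent is the change of amine end, a 2.7-fold lower number from compound 2 to compound 3 (0.43 log units; beyond the scatter), which was only modest. The estimated change is a 1.2-fold higher number from compound 3 to compound 4 (0.07 log units; within the scatter), so no step beyond the scatter is expected. Compound 4 is estimated at 2800 nM, with an expected range of 1100 nM to 6500 nM.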

Compound 4, half-maximal inhibitory concentration: 1820 nM
Compound 4: the middle estimate sits 1.5-fold (0.19 log units) above what was measured; low and high end bracket the measured number.
By their numbers in this assay, from the lowest: compounds 4 and 3 (each within the scatter of the next); then compound 2. At a limit, above all of these: compound 1.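

Diethylamino and dimethylamino at this place on the chain cannot be told apart in this assay (a 1.3-fold lower number from compound 3 to compound 4 (0.12 log units; within the scatter)), so the larger of the two amine ends is accepted as well as the smaller. Compound 4 also gives a lower number than the 4-methylpiperazin-1-yl compound (a 3.6-fold lower number from compound 2 to compound 4 (0.55 log units; beyond the scatter)) and compound 1 (an at least 27-fold lower number from compound 1 to compound 4 (1.43 log units; beyond the scatter)). That last step starts from a limit of the assay, not a number: the limit of > 50000 nM in this assay, at which 1 of the 4 values shown sits.

Still open, as far as these compounds go, is how a pyrrolidine or morpholine ring at the chain end would compare, and whether a butyl chain carrying diethylamino would read the same.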